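The source may hold more compounds than are shown below. What is called first, only, known or untested is meant among the compounds shown, and "the series" means these compounds.

Measured compounds:
Compound 1 `c1ccc(CNCCCCN(C[C@H]2Cc3ccccc3CN2)[C@H]2CCCc3cccnc32)cc1` — in a functional assay on cells for agonist activity at C-X-C chemokine receptor type 4 (Homo sapiens), read by fluorescence and calcium flux, with a stated time of 90 s (on this read-out lower numbers stand for an effect already at smaller amounts and higher numbers for an effect only at larger amounts of compound), compound 1 gives > 30000 nM, which is a limit of the assay and not a number.
Compound 2 `c1ccc2c(c1)CN[C@@H](CN(CCCCNCC1CCCCC1)[C@H]1CCCc3cccnc31)C2` — in this assay compound 2 gives > 30000 nM, again a limit of the assay.
Compound 3 `c1ccc2c(c1)CN[C@@H](CN(CCCCNC1CCOCC1)[C@H]1CCCc3cccnc31)C2` — in this assay compound 3 gives > 30000 nM, likewise a limit of the assay.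

Compound 2 therefore stands exactly where its two companions stand: at the limit of > 30000 nM in this assay, at which 3 of the 3 values shown sit. Every value is a limit. For the measured compounds named here, no step between these compounds can therefore be read as a size: a step that the two limits leave unreadable from compound 1 to compound 2, a step that the two limits leave unreadable from compound 2 to compound 3 and a step that the two limits leave unreadable from compound 1 to compound 3 are all unreadable.

The unmeasured compound 4 `CC(C)(N)CCCN(C[C@H]1Cc2ccccc2CN1)[C@H]1CCCc2cccnc21` differs from compound 2 in a single place: 1-amino-1-methylethyl in place of ((cyclohexylmethyl)amino)methyl on a saturated chain carbon, three bonds along the chain from an amine nitrogen. Going by the values given here, no measured step involves this kind of change, so nothing here points to an effect in either direction; the only guidance is that all three measured compounds, with quite different groups at the outer amine, sit at the same limit in this assay. On that basis compound 4 is expected to behave no differently, with an expected step of a number no higher from compound 2 to compound 4 (the limit leaves the size open) and an estimated value of 30000 nM, somewhere between 10000 nM and 100000 nM, most likely reported as a limit again.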

Compound 4, half-maximal effective concentration: > 30000 nM
Compound 4 gave a limit, no number (the forecaster's own chance of this, stated with the estimate: 85%); the middle value lies on the limit itself.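

In this assay compound 4 gives > 30000 nM which is a limit and not a number. No step among compound 1, compound 2, compound 3 and compound 4 can therefore be read, and all four stand together: the limit of > 30000 nM in this assay, at which 4 of the 4 values shown sit.

Still open is whether any of these compounds would give a real number on this read-out, and whether their different groups would then separate them.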